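Swapping the aryl group on the triazole nitrogen

This account rests on a few compounds, and the source may have more. Where it says the series, first, only, none or still open, it means among the compounds named here.

Compound 2 `Cc1cc(C)cc(-n2nncc2CN2C(=O)C3(C(C#N)=C(N)Oc4c3c3nc5ccccc5nc3c3ccccc43)c3ccccc32)c1` carries a 3,5-dimethylphenyl on the nitrogen of a five-membered aromatic ring with three nitrogens. In a functional assay on A549 cells (Homo sapiens) for antiproliferative activity, read by MTT assay, with a stated time of 48 h (a higher number here means a weaker inhibitor, a lower number a stronger inhibitor), compound 2 gives > 50000 nM, which is a limit of the assay and not a number. Its closest measured relative is compound 1 `N#CC1=C(N)Oc2c(c3nc4ccccc4nc3c3ccccc23)C12C(=O)N(Cc1cnnn1-c1ccccc1Cl)c1ccccc12`, which bears a 2-chlorophenyl at that same nitrogen; in this assay compound 1 gives 42600 nM. Within the data shown here, the only measured step, an at least 1.1-fold higher number from compound 1 to compound 2 (0.06 log units; that floor lies within the scatter), connects these two, and the limit of > 50000 nM in this assay, at which 1 of the 2 values shown sits, means that step has only a floor, not a size. Compound 3 `N#CC1=C(N)Oc2c(c3nc4ccccc4nc3c3ccccc23)C12C(=O)N(Cc1cnnn1-c1ccc(Cl)c(Cl)c1)c1ccccc12` is the next variation: 3,4-dichlorophenyl in place of 3,5-dimethylphenyl on an aromatic nitrogen. Both measured compounds sit at the weak end of the scale, and a chlorinated phenyl is already present in compound 1 with 42600 nM, so little movement is expected. The step from compound 2 to compound 3 is estimated as an at least 1.1-fold lower number from compound 2 to compound 3 (0.04 log units; that floor lies within the scatter), essentially no change beyond the scatter. For compound 3 the expected result in this assay is 45000 nM, with a likely range from 20000 nM to 100000 nM, and a real chance that only a limit is reported again.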

Compound 3, half-maximal inhibitory concentration: > 50000 nM
Compound 3: no number, only a limit (the forecaster's own chance of this, stated with the estimate: 45%); middle value at least 1.1-fold (0.04 log units) away from the limit.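

Compound 3 adds a third substituted phenyl at this nitrogen and a second result that is only a limit of the assay, so 3,4-dichlorophenyl and 3,5-dimethylphenyl both leave this assay without a number. Among these compounds, the step between compound 2 and compound 3 cannot be read, as both ends are limits, while the one readable step, replacing 2-chlorophenyl with 3,4-dichlorophenyl, is an at least 1.1-fold higher number from compound 1 to compound 3 (0.06 log units; that floor lies within the scatter), which does not separate the two compounds. Moving from one chlorine to two, and to different ring positions, therefore shows no gain in activity, but the measurements can only go so far at this end of the scale: the limit of > 50000 nM in this assay, at which 2 of the 3 values shown sit.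

What the compounds shown leave open is whether any group on this nitrogen can bring the number well down from the weak end of the scale, since all three carry a phenyl ring with chlorine or methyl substituents. An amine or a carboxylic acid on that phenyl ring, or a plain butyl chain in its place, could test whether this position matters for activity at all.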